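The source may hold more compounds than are shown below. What is called first, only, known or untested is meant among the compounds shown, and "the series" means these compounds.

Series of three measured analogues and one open compound, all sharing the same stilbene-chalcone core and differing only in the group on the carbonyl carbon. In an assay on isolated protein for inhibition of Amine oxidase [flavin-containing] B (Homo sapiens), read by fluorescence, with a stated time of 15 min (on this read-out lower numbers stand for stronger inhibition and higher numbers for weaker inhibition), compound 1 `COc1ccc(/C=C/c2cc(OC)cc(OC)c2/C=C/C(=O)c2cc3cc(Br)cc(OC)c3oc2=O)cc1` gives > 60000 nM, which is a limit of the assay and not a number (the limit of > 60000 nM in this assay, at which 1 of the 3 values shown sits). In the same assay compound 2 `CCOc1ccc2cc(C(=O)/C=C/c3c(/C=C/c4ccc(OC)cc4)cc(OC)cc3OC)c(=O)oc2c1` gives 48100 nM and compound 3 `COc1ccc(/C=C/c2cc(OC)cc(OC)c2/C=C/C(=O)c2cc3ccc(Br)cc3oc2=O)cc1` gives 55300 nM. Among the measured compounds shown here, compound 3 thus holds the higher of the two numbers read, with compound 2 nearest; the one step measured between them, a 1.1-fold higher number from compound 2 to compound 3 (0.06 log units; within the scatter), is within the scatter, so neither compound can be set apart from the other.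

Compound 4 `COc1ccc(/C=C/c2cc(OC)cc(OC)c2/C=C/C(=O)c2cc3cccc(C)c3oc2=O)cc1` is not yet measured. Relative to compound 3 the change is a group of 12 heavy atoms (10 carbon, 2 oxygen; one six-membered aromatic ring of carbon only, one six-membered aromatic ring with 1 hetero atom) in place of a group of 12 heavy atoms (9 carbon, 2 oxygen, 1 bromine; one six-membered aromatic ring of carbon only, one six-membered aromatic ring with 1 hetero atom), on a carbonyl carbon. For the measured compounds named here, the only measured step that bears on it is a 1.1-fold higher number from compound 2 to compound 3 (0.06 log units; within the scatter), an exchange of one substituent for another on the aromatic carbon of that group, and it moved the number by less than the scatter. Both measured numbers lie close to the limit at which compound 1 sits. On this basis no step beyond the scatter is expected from compound 3 to compound 4 in this assay, i.e. a 1.0-fold lower number from compound 3 to compound 4 (0.00 log units; within the scatter), and compound 4 is estimated at 55000 nM, in the range 20000 nM to 130000 nM.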

Compound 4, half-maximal inhibitory concentration: 20000 nM
For compound 4 the middle estimate is 2.8-fold (0.44 log units) above the measured one, within the range that was stated.
By their numbers in this assay, from the lowest: compound 4; then compounds 2 and 3 (each within the scatter of the next). At a limit, above all of these: compound 1.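

In this assay, the group on a carbonyl carbon now shows a change that lies beyond the scatter: a 2.8-fold lower number from compound 3 to compound 4 (0.44 log units; beyond the scatter). The other measured exchange in this group, a 1.1-fold higher number from compound 2 to compound 3 (0.06 log units; within the scatter), stayed within the scatter, so the new result is the only sign so far that the number responds to a change here, and the step is modest. Leaving and entering groups have the same count of heavy atoms, rings, double bonds outside aromatic rings and hydrogen-bond acceptors, and differ in their atoms (9 carbon, 2 oxygen, 1 bromine against 10 carbon, 2 oxygen), but no measured property accounts for the step.

This single pair cannot separate the loss of the bromine from the gain of the carbon, so it remains unclear which of the two carries the step. On these data alone, it also remains open whether an amine, a carboxylic acid or a longer chain on this group would take the number further down from compound 4 at 20000 nM or leave it unchanged.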